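Cytotoxicity notes: aryl exchange on the oxazole-bearing series

The source may hold more compounds than are shown below. What is called first, only, known or untested is meant among the compounds shown, and "the series" means these compounds.

Compound 1 `Cc1oc(-c2c(Cl)cccc2Br)nc1CN1CCC(C(=O)NCCCN2C[C@H](C)C[C@H](C)C2)CC1` is the reference point for this step. Among the measured compounds shown here, in an ADME assay on Huh7.5.1 cells (Homo sapiens) for cytotoxicity, read by ATP content, with a stated time of 48 h (on this read-out higher numbers stand for lower toxicity in this test and lower numbers for higher toxicity in this test), compound 1 gives 12200 nM, the lowest of the three numbers measured so far. Compound 2 `Cc1ccccc1-c1nc(CN2CCC(C(=O)NCCCCN3C[C@H](C)C[C@H](C)C3)CC2)c(C)o1` gives 23100 nM in this assay, a gap to compound 1 that stays within the scatter of repeat measurements, so no order between these two is claimed. Compound 3 `Cc1ccccc1-c1nc(CN2CCC(C(=O)N3CCN(CCN(C)C)CC3)CC2)c(C)o1` gives 27200 nM, and here the gap to compound 1 lies beyond the scatter, so compound 3 reads as less toxic than compound 1 in this test.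

Compound 4 `Cc1cc(C)cc(-c2nc(CN3CCC(C(=O)NCCCN4C[C@H](C)C[C@H](C)C4)CC3)c(C)o2)c1` has not yet been measured. Relative to compound 1 the change is 3,5-dimethylphenyl in place of 2-bromo-6-chlorophenyl on an aromatic carbon. For the measured compounds named here, no measured pair shows this particular exchange, so the size of the step is open. Both a halogen-bearing and a halogen-free aryl group sit on the shared core within this small set, and the three measured values span a narrow band; nothing in the data points to a large move in either direction. The expectation for compound 4 is therefore a step of a 1.3-fold higher number from compound 1 to compound 4 (0.12 log units; within the scatter), small and roughly neutral, at most a modest shift toward lower toxicity. The estimate for compound 4 in this assay is 16000 nM, with a range from 8000 nM to 32000 nM.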

Compound 4, half-maximal cytotoxic concentration: 4050 nM
Compound 4: the middle estimate sits 4.0-fold (0.60 log units) above what was measured; measured number below the stated range.
By their numbers in this assay, from the lowest: compound 4; then compounds 1, 2 and 3 (each within the scatter of the next, the first and the last beyond it).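

In this assay, the aryl group on this aromatic carbon of the five-membered aromatic ring with 1 nitrogen and 1 oxygen proves able to move the read-out: 3,5-dimethylphenyl in place of 2-bromo-6-chlorophenyl gives a 3.0-fold lower number from compound 1 to compound 4 (0.48 log units; beyond the scatter), a shift toward higher toxicity in this test. Among the compounds shown here, this is the first step in the set that differs in one place, since compounds 2 and 3 differ from compound 1 in more than one place and gave no reading on this position alone. The step occurs with the heavy-atom count, the six-membered aromatic carbon ring and the absence of hydrogen-bond donors, acceptors and net charge all unchanged, so those counts do not track the read-out across this pair; the differences left are the loss of both halogens, the gain of two methyl groups and where the substituents stand on the ring.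

For the compounds shown here, the single exchange does not separate these differences, and an unsubstituted phenyl group on the same carbon of the core of compound 1 would give a further reference point. No measurement shown bears on the reason for this step.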